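Butyl for Methyl on the Aryl Alkyne

The source may report more compounds than this note shows. Statements on the series, on what has been measured and on what is new or still open speak of the compounds shown alone.

Compound 1 `Cc1ccc(C#Cc2cn(C/C=C\CN3C(=O)c4ccccc4C3=O)c(=O)[nH]c2=O)cc1` carries a 4-methylphenyl group on its alkyne. In a functional assay on MCF7 cells (Homo sapiens) for antiproliferative activity, read by MTT assay, with a stated time of 3 days (a higher number here means a weaker inhibitor, a lower number a stronger inhibitor), compound 1 gives > 100000 nM, a value that is a limit of the assay and not a number, sitting at the limit of > 100000 nM in this assay, at which 1 of the 2 values shown sits. Compound 2 `CCCCCC#Cc1cn(C/C=C/CN2C(=O)c3ccccc3C2=O)c(=O)[nH]c1=O` belongs to the same series and in this assay compound 2 gives 44000 nM. No single change joins compound 1 to compound 2, so their two values simply stand side by side.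

Compound 3 `CCCCc1ccc(C#Cc2cn(C/C=C\CN3C(=O)c4ccccc4C3=O)c(=O)[nH]c2=O)cc1` differs from compound 1 by propyl in place of hydrogen on a saturated chain carbon bound to an aromatic carbon. Going by the values given here, since compound 1 is known only as a limit, no measured step shows where this change leads. The step from compound 1 to compound 3 is expected to be an at least 1.4-fold lower number from compound 1 to compound 3 (0.15 log units; that floor lies within the scatter), a modest move if any. Compound 3 is therefore estimated at 70000 nM in this assay, with a range from 20000 nM to 250000 nM.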

Compound 3, half-maximal inhibitory concentration: 43000 nM
For compound 3 the middle estimate is 1.6-fold (0.21 log units) above the measured one, and the stated range covers the measured number.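

Methyl to butyl on the aryl alkyne, which turns 4-methylphenyl into 4-butylphenyl, gives the first readable step at this position: in this assay the change yields an at least 2.3-fold lower number from compound 1 to compound 3 (0.36 log units; beyond the scatter). Compound 3 gives a measured number, 43000 nM, so extending the chain at this saturated carbon bound to an aromatic carbon does move the read-out beyond the scatter. The true size of the step remains unknown, because the value of compound 1 is a limit of the assay and not a number: the limit of > 100000 nM in this assay, at which 1 of the 3 values shown sits.

The compounds shown leave open how far this trend runs, since a single change cannot establish whether a longer chain such as hexyl would lower the number further. They also leave open what an amine or a carboxylic acid in place of the butyl group would do.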